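The source may hold more compounds than are shown below. What is called first, only, known or untested is meant among the compounds shown, and "the series" means these compounds.

The study examines a small series sharing one core, tested in a functional assay (microsomes, liver) with Rattus norvegicus as the target; on this read-out higher numbers stand for weaker inhibition and lower numbers for stronger inhibition. Compound 1, `CC(C)=Cc1c(C)c(N)c(C)c2c1OC(C)(C)C2`, gives 300 nM in this assay. Compound 2, `Cc1c(C)c2c(c(C)c1N)CC(C)(CSc1ccccc1)O2`, gives 270 nM in this assay. The two values of compound 1 and compound 2 lie within the scatter of each other, so nothing separates them on the numbers shown. Compound 3, `Cc1c(C)c2c(c(C)c1N)CC(C)(CSc1ccncc1)O2`, has not yet been measured; the difference from compound 2 is pyridin-4-yl in place of phenyl on a sulfur. Within the data shown here, no measured pair in this set carries the same change, so there is no step from which to read its size. The estimate for compound 3 therefore stays close to compound 2, with a step of a 1.3-fold higher number from compound 2 to compound 3 (0.11 log units; within the scatter) expected, small and possibly toward a weaker value but not clearly beyond the scatter. Compound 3 is expected to give about 350 nM in this assay, in a range from 150 nM to 800 nM.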

Compound 3, half-maximal inhibitory concentration: 630 nM
Compound 3: middle estimate off by 1.8-fold (0.26 log units), on the low side, and the stated range covers the measured number.
By their numbers in this assay, from the lowest: compounds 2 and 1 (each within the scatter of the next); then compound 3.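

Among these compounds, this is the first step whose size can be read: in this assay putting pyridin-4-yl in place of phenyl on the sulfur gives a 2.3-fold higher number from compound 2 to compound 3 (0.37 log units; beyond the scatter) and so is a modest change, but one that lies beyond the scatter. The position therefore responds to a single ring carbon being replaced by nitrogen, even though the heavy-atom count stays the same and the only counted gain is one hydrogen-bond acceptor. Nothing available bears on why the number moves in this direction.

From the compounds shown here alone, it remains open whether the step follows from the ring nitrogen as such or from its place in the ring, which pyridin-3-yl or pyridin-2-yl on the same sulfur could test. Going by these compounds, how the position would answer to a saturated ring such as cyclohexyl, or to a simple chain such as butyl, also remains open.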